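Indole or substituted phenyl on the shared core

A few compounds are considered here, and "the series" means these few. Any claim that something is new, unique, unknown or untested is made for them only; others in the source may bear on it.

Values in a functional assay on HeLa cells (Homo sapiens) for inhibition, read by CCK-8 assay, with a stated time of 48 h; on this read-out higher numbers stand for weaker inhibition and lower numbers for stronger inhibition:
- compound 1 `COc1cc(-c2ccnc3cc(-c4ccc5c(ccn5C)c4)nn23)cc(OC)c1OC`: 19 nM
- compound 2 `COc1cc(-c2ccnc3cc(-c4ccc(C(F)(F)F)cc4)nn23)cc(OC)c1OC`: 1840 nM
- compound 3 `C=Cc1ccc(-c2cc3nccc(-c4cc(OC)c(OC)c(OC)c4)n3n2)cc1`: 882 nM

Compound 3 stands second highest of the three numbers at 882 nM. Its nearest neighbour is reached by a 2.1-fold lower number from compound 2 to compound 3 (0.32 log units; beyond the scatter), a modest step between the two substituted phenyl groups. The next entry is compound 4 `COc1cc(-c2ccnc3cc(-c4ccc5ccn(C)c5c4)nn23)cc(OC)c1OC`, with 1-methyl-1H-indol-6-yl in place of 4-vinylphenyl on an aromatic carbon.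

For the measured compounds named here, no measured compound carries 1-methyl-1H-indol-6-yl, so the closest evidence comes from 1-methyl-1H-indol-5-yl. Both large steps away from that group point the same way: a 46-fold higher number from compound 1 to compound 3 (1.67 log units; beyond the scatter) and a 97-fold higher number from compound 1 to compound 2 (1.99 log units; beyond the scatter). Read backwards, they favour a move to a lower number on leaving 4-vinylphenyl. How far this carries over to the 1-methyl-1H-indol-6-yl group is unmeasured, so a large but smaller step is expected in this assay, namely a 13-fold lower number from compound 3 to compound 4 (1.10 log units; beyond the scatter). For compound 4 the estimated value is 70 nM, with an expected range of 12 nM to 400 nM.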

Compound 4, half-maximal inhibitory concentration: 187 nM
Estimate against measurement, compound 4: 2.7-fold (0.43 log units) below, within the range that was stated.
By their numbers in this assay, from the lowest: compound 1; then compound 4; then compound 3; then compound 2.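

In this assay the change from 1-methyl-1H-indol-5-yl to 1-methyl-1H-indol-6-yl on this aromatic carbon, with the same atoms entering, gives a 9.8-fold higher number from compound 1 to compound 4 (0.99 log units; beyond the scatter); the low number of compound 1 therefore depends on where the indole is attached and not only on an indole being present. The 1-methyl-1H-indol-6-yl group still compares well with both substituted phenyl groups, with a 4.7-fold lower number from compound 3 to compound 4 (0.67 log units; beyond the scatter) and a 9.8-fold lower number from compound 2 to compound 4 (0.99 log units; beyond the scatter), so among these four compounds both indoles give lower numbers than both phenyl groups. No measurement shown accounts for the difference between the two indole attachments.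

Still open, as far as these compounds go, is whether the methyl on the indole nitrogen contributes, which a 1H-indol-5-yl group would test. Also open, from the compounds shown here alone, is how a 1-methyl-1H-indol-4-yl group or a phenyl carrying a dimethylamino group would compare at this position.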